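Pentyl in place of phenyl on a weak lipase inhibitor

A few compounds are considered here, and "the series" means these few. Any claim that something is new, unique, unknown or untested is made for them only; others in the source may bear on it.

compound 1 `COc1cnc(C(=O)CCCCCCc2ccccc2)o1`: > 10000 nM
compound 2 `O=C(CCc1ccccc1)c1nc2ncccc2o1`: 18200 nM

Going by the values given here, in an assay on HEK-293T cells for inhibition of diacylglycerol lipase-alpha (Homo sapiens), read by colorimetric assay (a lower number here means a stronger inhibitor, a higher number a weaker inhibitor), compound 2 gives 18200 nM, the only number among the two results. For compound 1 the result in this assay is > 10000 nM, which is a limit rather than a number, placing it at the limit of > 10000 nM in this assay, at which 1 of the 2 values shown sits. Compound 3 `CCCCCCCC(=O)c1nc2ncccc2o1` carries pentyl in place of phenyl on a saturated chain carbon, two bonds along the chain from a carbonyl carbon. Among the compounds with values here, no measured pair shows such a change, so the expected step from compound 2 to compound 3 is a 1.4-fold higher number from compound 2 to compound 3 (0.14 log units; within the scatter), a small shift toward weaker inhibition that may not exceed the scatter. Compound 3 is therefore estimated at 25000 nM, within 8000 nM to 80000 nM.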

Compound 3, half-maximal inhibitory concentration: 631 nM
For compound 3 the middle estimate is 40-fold (1.60 log units) above the measured one; measured number outside the range, below it.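

At this position, on a saturated chain carbon, two bonds along the chain from a carbonyl carbon, an aromatic ring is not needed for inhibition in this assay. Pentyl in place of phenyl gives a 29-fold lower number from compound 2 to compound 3 (1.46 log units; beyond the scatter) and is the first change measured here, showing that this place responds strongly to what it carries. Nothing shown accounts for the size of this gain.

On these data alone, whether a longer chain would strengthen inhibition further remains open. So does whether an amine or a carboxylic acid at the chain end would be tolerated.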